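Aryl ketone variation in a weakly cytotoxic series

The source may report more compounds than this note shows. Statements on the series, on what has been measured and on what is new or still open speak of the compounds shown alone.

Compound 1 `COc1cc(-c2nnc3n2NC(c2ccco2)C(C(=O)c2ccc(F)c(F)c2)S3)cc(OC)c1OC` gives 73200 nM in a functional assay on MCF7 cells (Homo sapiens) for cytotoxicity, read by MTT assay, with a stated time of 48 h; a lower number here means a stronger inhibitor, a higher number a weaker inhibitor. Compound 2 `COc1cc(-c2nnc3n2NC(c2ccco2)C(C(=O)c2ccc([N+](=O)[O-])cc2)S3)cc(OC)c1OC` reaches only the limit of this assay, > 100000 nM. Compound 3 `COc1cc(-c2nnc3n2NC(c2ccco2)C(C(=O)c2ccc(-c4ccccc4)cc2)S3)cc(OC)c1OC` likewise stands at a limit in this assay, > 100000 nM. The step of an at least 1.3-fold higher number from compound 1 to compound 2 (0.13 log units; that floor lies within the scatter) and the step of an at least 1.3-fold higher number from compound 1 to compound 3 (0.13 log units; that floor lies within the scatter) are therefore floors, and the step that the two limits leave unreadable from compound 2 to compound 3 cannot be read at all, since both ends sit at the limit of > 100000 nM in this assay, at which 2 of the 3 values shown sit. Compound 3 thus stands at the top of the numbers shown, with no number of its own.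

Compound 4 `COc1cc(-c2nnc3n2NC(c2ccco2)C(C(=O)c2ccco2)S3)cc(OC)c1OC` carries furan-2-yl in place of 4-phenylphenyl on a carbonyl carbon. Within the data shown here, the measured steps touching the same place, from compound 1 to compound 3 and from compound 2 to compound 3, show only that two aryl ketones sit at the limit while the difluorophenyl ketone of compound 1 gives a readable but weak number; no step measures a furan-2-yl ketone. The expected step of an at least 1.1-fold lower number from compound 3 to compound 4 (0.04 log units; that floor lies within the scatter) is therefore of unreadable size and cannot be placed beyond the scatter in either direction. Compound 4 is estimated at 90000 nM in this assay. The estimated range for compound 4 runs from 40000 nM to 200000 nM, with a fair chance that only a limit is reported.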

Compound 4, half-maximal inhibitory concentration: > 100000 nM
Compound 4: only a limit was reported; the forecaster's own chance of this, stated with the estimate: 50%; middle value at least 1.1-fold (0.04 log units) away from the limit.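

Among these compounds, a furan-2-yl ketone on this carbonyl carbon brings a five-membered aromatic ring with 1 hetero atom into a position that had so far held only six-membered aromatic rings. Compound 4 gives > 100000 nM in this assay, which is a limit and not a number. The ceiling therefore now holds a furan-2-yl ketone as well as two larger aryl ketones, and the only readable comparison is the floor an at least 1.3-fold higher number from compound 1 to compound 4 (0.13 log units; that floor lies within the scatter), while the steps linking compound 4 to the other two limit compounds cannot be read: the limit of > 100000 nM in this assay, at which 3 of the 4 values shown sit.

Among the compounds shown here, compound 1 remains the only compound with a number, so it stays open whether its 3,4-difluorophenyl ketone truly differs from the other three groups beyond the scatter, and no order can be given among the compounds at the limit. Going by these compounds, it also stays open whether a 4-aminophenyl ketone, a 4-carboxyphenyl ketone or a simple alkyl chain on this carbonyl carbon would give a readable value in this assay.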